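Moving the carboxyl on a sulfur-linked phenyl

This account rests on a few compounds, and the source may have more. Where it says the series, first, only, none or still open, it means among the compounds named here.

Measured so far in a functional assay (ileum) for agonist activity, with Cavia porcellus as the target; on this read-out lower numbers stand for lower potency and higher numbers for higher potency (the scale is a negative logarithm)
- Compound 1 `CCCCC/C=C\C/C=C\C=C\C=C\[C@@H](SCC(=O)O)[C@@H](O)CCCC(=O)O` gives 8.5 here
- Compound 2 `CCCCC/C=C\C/C=C\C=C\C=C\[C@@H](Sc1ccccc1C(=O)O)[C@@H](O)CCCC(=O)O` gives 6.9 here

Of the two measured compounds, compound 2 holds the lower number. Compound 3 `CCCCC/C=C\C/C=C\C=C\C=C\[C@@H](Sc1cccc(C(=O)O)c1)[C@@H](O)CCCC(=O)O` carries 3-carboxyphenyl in place of 2-carboxyphenyl on a sulfur. For the measured compounds named here, the only measured step nearby, a number 1.60 log units lower from compound 1 to compound 2 (beyond the scatter), was large, but it replaced carboxymethyl and does not test this change, so no step beyond the scatter is expected. The expected change is small, a number 0.10 log units lower from compound 2 to compound 3 (within the scatter) by estimate, with its direction uncertain. In this assay the estimate for compound 3 is 6.8 with an expected range from 6 to 7.6 for the coming measurement.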

Compound 3, negative logarithm of the half-maximal effective concentration: 8.2
Beside the measured number, compound 3's estimate is 1.40 log units below it, and the stated range ends below it.
By their numbers in this assay, from the lowest: compound 2; then compounds 3 and 1 (each within the scatter of the next).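

In this assay, the same atoms joined differently on the sulfur give a number 1.30 log units higher from compound 2 to compound 3 (beyond the scatter), so the loss seen with 2-carboxyphenyl does not hold for every carboxyphenyl group at this place. With 3-carboxyphenyl in place of carboxymethyl on the sulfur, the comparison gives a number 0.30 log units lower from compound 1 to compound 3 (within the scatter). Nothing available here explains why the two carboxyphenyl groups part so widely. Still open, from the compounds shown here alone, is how 4-carboxyphenyl on this sulfur would compare, and whether a plain phenyl without the carboxylic acid would keep any of this potency.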